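A few compounds are considered here, and "the series" means these few. Any claim that something is new, unique, unknown or untested is made for them only; others in the source may bear on it.

Compound 1 `CC(C)(C)c1cc(NC(=O)[C@@H]2CCCCN2C2CC2)no1`: 0.183 h
Compound 2 `CC(C)(C)c1cc(NC(=O)[C@@H]2CCCCN2C(=O)c2ccc(Cl)cc2)no1`: 1.25 h
Compound 3 `CC(C)(C)c1cc(NC(=O)[C@@H]2CCCCN2C(=O)C2CCCCC2)no1`: 0.483 h

In an ADME assay (liver) for metabolic stability, with Liver microsome (Homo sapiens) as the target, read by LC-MS, using microsomes and NADPH, tested at 1 uM (on this read-out higher numbers stand for a longer-lived compound and lower numbers for a shorter-lived compound), compound 1 stands lowest of the three numbers; compound 3 is nearest and compound 2 furthest from it. Compound 4 `CC(C)(C)c1cc(NC(=O)[C@@H]2CCCCN2C(=O)CC2CCOCC2)no1` differs from compound 1 in one place: ((oxan-4-yl)methyl)carbonyl in place of cyclopropyl on an amine nitrogen in a ring. Going by the values given here, two measured steps bear on this change, a 6.8-fold higher number from compound 1 to compound 2 (0.83 log units; beyond the scatter) and a 2.6-fold higher number from compound 1 to compound 3 (0.42 log units; beyond the scatter), each of which also replaced the cyclopropyl with a carbonyl-bearing group on the same nitrogen. A rise beyond the scatter is therefore expected for compound 4, modest in size, because a 2.6-fold higher number from compound 1 to compound 3 (0.42 log units; beyond the scatter) came from the closer non-aromatic case. Compound 4 is estimated at 0.55 h, within 0.25 h to 1.2 h. This expected change amounts to a 3.0-fold higher number from compound 1 to compound 4 (0.48 log units; beyond the scatter).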

Compound 4, half-life: 1.83 h
Estimate against measurement, compound 4: 3.3-fold (0.52 log units) below; the measured number lies above the stated range.
By their numbers in this assay, from the lowest: compound 1; then compound 3; then compounds 2 and 4 (each within the scatter of the next).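

In this assay, the change on the ring nitrogen gives a 10-fold higher number from compound 1 to compound 4 (1.00 log units; beyond the scatter), and a carbonyl group without an aromatic ring can therefore match the chlorophenyl amide, with a 1.5-fold higher number from compound 2 to compound 4 (0.17 log units; within the scatter). The non-aromatic groups on this carbonyl are not interchangeable: (oxan-4-yl)methyl in place of cyclohexyl gives a 3.8-fold higher number from compound 3 to compound 4 (0.58 log units; beyond the scatter). No measurement shown here accounts for this difference. On these data alone, that last step changes both the ring and the link to the carbonyl, so the contribution of each remains open. A cyclohexylmethyl group on the same carbonyl carbon would separate the two.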